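From pyridin-4-yl to 4-hydroxyphenyl on a compound at the limit

The source may report more compounds than this note shows. Statements on the series, on what has been measured and on what is new or still open speak of the compounds shown alone.

In a functional assay on HCT-116 cells (Homo sapiens) for antiproliferative activity, read by MTT assay, with a stated time of 24 h (a higher number here means a weaker inhibitor, a lower number a stronger inhibitor), compound 1 `COc1ccc(-c2noc(-c3ccncc3)n2)cc1OC1CCCC1` gives > 1000000 nM, which is a limit and not a number. Compound 2 `COc1ccc(-c2noc(Cc3c[nH]c4ccccc34)n2)cc1OC1CCCC1` gives > 1000000 nM, also a limit. Compound 3 `COc1cc(-c2noc(-c3ccncc3)n2)ccc1OCc1ccccc1` gives > 1000000 nM, again a limit. For the measured compounds named here, compound 1 thus stands at the limit of > 1000000 nM in this assay, at which 3 of the 3 values shown sit, and no step between measured compounds is available as a guide. Compound 4 `COc1ccc(-c2noc(-c3ccc(O)cc3)n2)cc1OC1CCCC1` brings one change: 4-hydroxyphenyl in place of pyridin-4-yl on an aromatic carbon, with 4-hydroxyphenyl in place of pyridin-4-yl on an aromatic carbon. Going by the values given here, the only anchor is compound 1 with its limit of > 1000000 nM, so only a small move is expected. The estimated step is an at least 2.0-fold lower number from compound 1 to compound 4 (0.30 log units; that floor lies within the scatter), a modest shift towards a lower number in this assay. Compound 4 is expected at 500000 nM, with an estimated range of 100000 nM to 1000000 nM.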

Compound 4, half-maximal inhibitory concentration: 270 nM
Estimate against measurement, compound 4: 1900-fold (3.27 log units) above; the measured number lies below the stated range.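

Placing 4-hydroxyphenyl instead of pyridin-4-yl on this aromatic carbon gives an at least 3700-fold lower number from compound 1 to compound 4 (3.56 log units; beyond the scatter) and shows that a change at this one position is enough to bring the core of compound 1 off the limit. Compound 4 is the only compound shown with a measured number. Compound 1 has only a limit, so the true step may be larger still: the limit of > 1000000 nM in this assay, at which 3 of the 4 values shown sit.

On these data alone, whether the hydroxyl group itself matters stays open, since plain phenyl or 4-aminophenyl at this position would separate its contribution from that of the all-carbon ring.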